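The compounds below may be only part of what the source reports. "The series", "measured", "known", "first", "only" and "open" are said of these compounds alone.

In a functional assay on cells (Mus musculus) for cytotoxicity, read by MTT assay, with a stated time of 72 h (on this read-out higher numbers stand for weaker inhibition and lower numbers for stronger inhibition), compound 1 (`COc1cc(O)c(C)c2c1CC[C@H](c1ccc(O)cc1)O2`) gives 59100 nM and compound 2 (`COc1ccc(CCC(=O)c2ccc(O)cc2)c(OC)c1`) gives 32200 nM. These two values lie within the usual scatter of each other, so compound 1 cannot be told apart from compound 2. Compound 3 (`Cc1c(O)ccc2c1O[C@@H](c1ccc(O)cc1)CC2`) carries hydrogen in place of methoxy on an aromatic carbon of the core of compound 1 (hydrogen in place of methoxy on an aromatic carbon). Going by the values given here, no measured pair shows this change, so only a small shift is expected: the estimated step, a 1.3-fold lower number from compound 1 to compound 3 (0.12 log units; within the scatter), leans toward stronger inhibition but stays within the scatter. For compound 3 the expected value in this assay is 45000 nM, with an estimated range from 16000 nM to 110000 nM.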

Compound 3, half-maximal inhibitory concentration: 40200 nM
Compound 3: the middle estimate sits 1.1-fold (0.05 log units) above what was measured, and the stated range covers the measured number.
By their numbers in this assay, from the lowest: compounds 2, 3 and 1 (each within the scatter of the next).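

In this assay, going by these compounds alone, hydrogen in place of methoxy on an aromatic carbon, meta to a hydroxy group and para to a methyl group, gives a 1.5-fold lower number from compound 1 to compound 3 (0.17 log units; within the scatter), the only measured pair for this change. At this position, the methoxy group can therefore be lost without a shift that can be told apart from the scatter. Nothing at hand explains this result. Going by these compounds, whether an amine or a carboxylic acid on this same carbon would move the number beyond the scatter stays open.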